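The source may report more compounds than this note shows. Statements on the series, on what has been measured and on what is new or still open speak of the compounds shown alone.

Compound 1, `Cc1cc(NS(=O)(=O)c2ccc(-c3cnc(C4CC4)o3)cc2)ccc1Cl`, in a functional assay on cells (leukaemia cell line, Homo sapiens) for inhibition, read by sulforhodamine B assay, with a stated time of 48 h; on this read-out higher numbers stand for lower toxicity in this test and lower numbers for higher toxicity in this test: > 100000 nM, a limit.
Compound 2, `O=S(=O)(Nc1cc(Cl)ccc1Cl)c1ccc(-c2cnc(C3CC3)o2)cc1`, in this assay: > 100000 nM, a limit.
Compound 3, `Cc1cc(Cl)ccc1NS(=O)(=O)c1ccc(-c2cnc(C3CC3)o2)cc1`, in this assay: > 100000 nM, a limit.

Compound 1 stands only at a limit in this assay, as do the other two, so that all three values sit at the limit of > 100000 nM in this assay, at which 3 of the 3 values shown sit. The steps a step that the two limits leave unreadable from compound 1 to compound 2, a step that the two limits leave unreadable from compound 1 to compound 3 and a step that the two limits leave unreadable from compound 2 to compound 3 therefore carry no readable size. Compound 4, `O=S(=O)(Nc1ccc(I)c(Cl)c1)c1ccc(-c2cnc(C3CC3)o2)cc1`, differs from compound 1 by 3-chloro-4-iodophenyl in place of 4-chloro-3-methylphenyl on a sulfonamide nitrogen. The measured steps bearing on this change are those from compound 1 to compound 2 and compound 3, and none of them shows a movement away from the limit. The estimate for compound 4 is therefore a step that the limit leaves unreadable from compound 1 to compound 4, that is none beyond the scatter. Compound 4 is expected at 150000 nM, in the range 50000 nM to 600000 nM.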

Compound 4, concentration lethal to 50% of the cells: > 100000 nM
Compound 4 gave a limit, no number (the forecaster's own chance of this, stated with the estimate: 85%); the middle value lies beyond the limit too.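

Compound 4 gives only a limit in this assay, as do compound 1, compound 2 and compound 3, so no step among them can be read: the limit of > 100000 nM in this assay, at which 4 of the 4 values shown sit.

The compounds shown leave open whether any group on the sulfonamide nitrogen would give a measurable value in this assay.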